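Pyridin-3-yl in Place of Pyridazin-3-yl: Expecting Compound 4

This account rests on a few compounds, and the source may have more. Where it says the series, first, only, none or still open, it means among the compounds named here.

Measured so far:
Compound 1, `CN(C)C(=O)[C@H]1CCC[C@@H](c2cccc(-n3ncc(C(=O)O)c3C3CC3)c2)C1`, gives 1700 nM.
Compound 2, `CCCC1CCCCN1C(=O)c1cccc(-c2cccc(-n3ncc(C(=O)O)c3C3CC3c3cccnn3)c2)c1`, gives 2800 nM.
Compound 3, `CN(CC1CC1)C(=O)c1cccc(-c2cccc(-n3ncc(C(=O)O)c3C3CC3)c2)c1F`, gives 2200 nM.

All three values come from an assay on BEAS-2B cells for activation of nuclear factor erythroid 2-related factor 2 (Homo sapiens), read by MTT assay, with a stated time of 48 h; on this read-out higher numbers stand for an effect only at larger amounts of compound and lower numbers for an effect already at smaller amounts. Compound 2 has the highest number of the three, yet its gaps to compound 3 and to compound 1 both lie within the usual scatter of repeated measurements, so the three compounds cannot be told apart on these numbers. Among the measured compounds shown here, no pair among them differs in just one place, so no single structural change has a measured effect here.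

Compound 4, `CCCC1CCCCN1C(=O)c1cccc(-c2cccc(-n3ncc(C(=O)O)c3C3CC3c3cccnc3)c2)c1`, is the compound still to be measured. It differs from compound 2 in one place: pyridin-3-yl in place of pyridazin-3-yl on a saturated ring carbon. The rest of the molecule, including the shared core and the acid, is unchanged.

For the measured compounds named here, nothing among the measured compounds shows what this particular exchange does, so the expectation rests on the change being small and on compound 2 itself. Compound 4 is estimated to come close to compound 2 in this assay, with the step from compound 2 to compound 4 expected to be a 1.1-fold lower number from compound 2 to compound 4 (0.05 log units; within the scatter), that is, nothing beyond the scatter. The estimate for compound 4 is 2500 nM, with a range from 1000 nM to 6000 nM.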

Compound 4, half-maximal effective concentration in the nuclear factor erythroid 2-related factor 2 assay: 3200 nM
Estimate against measurement, compound 4: 1.3-fold (0.11 log units) below; the measured number falls inside the stated range.
By their numbers in the nuclear factor erythroid 2-related factor 2 assay, from the lowest: compounds 1, 3, 2 and 4 (each within the scatter of the next).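

In the nuclear factor erythroid 2-related factor 2 assay, the exchange gives a 1.1-fold higher number from compound 2 to compound 4 (0.06 log units; within the scatter), so compound 2 and compound 4 cannot be told apart on this read-out. Among the compounds shown here, this is the first comparison here that differs in one place, and it shows that, on this saturated ring carbon of the three-membered ring, pyridin-3-yl and pyridazin-3-yl are not distinguished by the cell read-out, even though a ring nitrogen gives way to carbon. The same exchange does register in a physicochemical assay for lipophilicity, read by HPLC, at pH 2 (on this read-out lower numbers stand for lower lipophilicity and higher numbers for higher lipophilicity), where compound 2 gives 2.9 and compound 4 gives 3.9 so that at this position lipophilicity can rise while the cell read-out shows no difference beyond the scatter: the measured distribution coefficient of compound 2, 2.9, and of compound 4, 3.9, a number 1.00 log units higher (beyond the scatter)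

Both compound 2 and compound 4 carry an aromatic ring with nitrogen at this place, so they cannot show whether a plain phenyl ring, an amine or a longer chain would be tolerated equally well in the nuclear factor erythroid 2-related factor 2 assay. For the compounds shown here, it also stays open whether the missing separation holds for this exchange alone, since only one pair of compounds with one shared remainder of the molecule speaks to it.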